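Phenethylsulfanyl in Place of Methylamino on the Shared Core

The source may hold more compounds than are shown below. What is called first, only, known or untested is meant among the compounds shown, and "the series" means these compounds.

Compound 2 `CNc1nc(=O)ccn1[C@@H]1O[C@H](COP(=O)(O)OP(=O)(O)O)[C@@H](O)[C@H]1O` is the starting point of this step. In an in vitro functional assay on 1321-N1 cells for agonist activity at P2Y purinoceptor 6 (Homo sapiens), read by scintillation proximity assay and inositol phosphate accumulation (on this read-out lower numbers stand for an effect already at smaller amounts and higher numbers for an effect only at larger amounts of compound), compound 2 gives only a limit, > 100000 nM, and not a number. Benzylsulfanyl stands where compound 2 carries methylamino in compound 1 `O=c1ccn([C@@H]2O[C@H](COP(=O)(O)OP(=O)(O)O)[C@@H](O)[C@H]2O)c(SCc2ccccc2)n1`, and in this assay compound 1 gives 6800 nM. Within the data shown here, the one measured step, an at least 14-fold higher number from compound 1 to compound 2 (1.16 log units; beyond the scatter), shows that the exchange of benzylsulfanyl for methylamino pushed the value out to the limit of the assay (the limit of > 100000 nM in this assay, at which 1 of the 2 values shown sits). Compound 3 `O=c1ccn([C@@H]2O[C@H](COP(=O)(O)OP(=O)(O)O)[C@@H](O)[C@H]2O)c(SCCc2ccccc2)n1` turns this kind of change around: phenethylsulfanyl in place of methylamino on an aromatic carbon. Phenethylsulfanyl is benzylsulfanyl with a longer chain, so a large drop in this assay is expected, roughly undoing the earlier step. The step expected here is an at least 12-fold lower number from compound 2 to compound 3 (1.09 log units; beyond the scatter). For compound 3 the estimate in this assay is 8000 nM, with a range from 2000 nM to 40000 nM.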

Compound 3, half-maximal effective concentration: 2500 nM
For compound 3 the middle estimate is 3.2-fold (0.51 log units) above the measured one, within the range that was stated.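

Placing phenethylsulfanyl on this aromatic carbon gives an at least 40-fold lower number from compound 2 to compound 3 (1.60 log units; beyond the scatter), so a second sulfur-linked group, and not benzylsulfanyl alone, restores a measurable effect where methylamino left none within range. On these data alone, that step starts from a limit and not from a number, so its true size is unknown: the limit of > 100000 nM in this assay, at which 1 of the 3 values shown sits. The length of the chain also counts, since benzyl in place of phenyl on the chain carbon bound to the sulfur gives a 2.7-fold lower number from compound 1 to compound 3 (0.43 log units; beyond the scatter) in this assay, a modest change but one beyond the usual scatter.

As far as these compounds go, whether a still longer chain, such as phenylpropylsulfanyl, would lower the number further remains open. Also open, from the compounds shown here alone, is whether the sulfur is needed at all, which benzylamino or benzyloxy at this position would show.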